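The compounds below may be only part of what the source reports. "The series", "measured", "known", "first", "only" and "open" are said of these compounds alone.

Working notes on the series. Compound 1 `OCCCCC#Cc1ccccc1C#Cc1ccccc1` is the open-chain diaryl diyne with a free hydroxyl at the end of the pentynol arm; in a functional assay on DU-145 cells (Homo sapiens) for cytotoxicity (a higher number here means a weaker inhibitor of growth, a lower number a stronger inhibitor of growth), compound 1 gives 5220 nM, the lowest of the two numbers recorded so far. Among the compounds with values here, compound 2 `COc1ccccc1C#Cc1ccccc1C#CCCCCO` carries a methoxy on one aromatic carbon, and in this assay compound 2 gives 14300 nM; the step of a 2.7-fold higher number from compound 1 to compound 2 (0.44 log units; beyond the scatter) is the only measured step in the set. The compound now in question, compound 3 `OCCCCC#Cc1ccccc1C#Cc1ccccn1`, differs from compound 1 by pyridin-2-yl in place of phenyl on a triple-bonded carbon. Within the data shown here, no measured step covers an aryl-for-heteroaryl exchange at the triple-bonded carbon, and the methoxy step from compound 1 to compound 2 does not bear directly on it, so the size and direction of the change in this assay cannot be read off the data. The working expectation is a step of about a 1.1-fold higher number from compound 1 to compound 3 (0.06 log units; within the scatter), within the scatter, and compound 3 is therefore estimated at 6000 nM, with a range from 2000 nM to 20000 nM.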

Compound 3, concentration for 50% growth inhibition: 9800 nM
Compound 3: the middle estimate sits 1.6-fold (0.21 log units) below what was measured, and the stated range covers the measured number.
By their numbers in this assay, from the lowest: compounds 1, 3 and 2 (each within the scatter of the next, the first and the last beyond it).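

Replacing phenyl with pyridin-2-yl on a triple-bonded carbon gives a 1.9-fold higher number from compound 1 to compound 3 (0.27 log units; within the scatter) in this assay and so, unlike the methoxy change, stays within the scatter. At this position, then, one ring carbon can give way to nitrogen, adding a hydrogen-bond acceptor, without a change in growth inhibition that these numbers can separate from repeat variation. No supporting measurement accompanies these compounds to explain the number for compound 3.

Still open, going by these compounds, is whether pyridin-3-yl or pyridin-4-yl on the same triple-bonded carbon would also stay within the scatter of compound 1, which would show whether the placement of the ring nitrogen matters. Also open, on these data alone, is whether an amine or a carboxylic acid on the pyridin-2-yl ring would move the number beyond the scatter in either direction.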